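The compounds below may be only part of what the source reports. "The series", "measured", "known", "first", "only" and "open" are said of these compounds alone.

Compound 1 `CC(C)=CC(=O)Nc1cc2c(N3CCCc4ccccc43)ncnc2cc1O[C@@H]1CCOC1`: 7910 nM
Compound 2 `C/C=C/C(=O)Nc1cc2c(N3CCCc4ccccc43)ncnc2cc1O[C@@H]1CCOC1`: 10800 nM

In a functional assay on A549 cells (Homo sapiens) for antiproliferative activity, read by MTT assay, with a stated time of 72 h (a higher number here means a weaker inhibitor, a lower number a stronger inhibitor), compound 2 gives 10800 nM, which is level within the scatter with compound 1 at 7910 nM. Neither compound can be ranked on these numbers. Compound 3 `CCC/C=C/C(=O)Nc1cc2c(N3CCCc4ccccc43)ncnc2cc1O[C@@H]1CCOC1` has not yet been measured. It differs from compound 2 by ethyl in place of hydrogen on a saturated chain carbon bound to a double-bonded chain carbon, which turns prop-1-en-1-yl into pent-1-en-1-yl on the carbonyl carbon. For the measured compounds named here, only one measured step bears on this: a 1.4-fold higher number from compound 1 to compound 2 (0.14 log units; within the scatter). It also alters the group on the carbonyl carbon, but it stays within the scatter. Going by the values given here, no measured compound carries pent-1-en-1-yl, so the evidence for this change is indirect. A step beyond the scatter in this assay is therefore not expected, in either direction. Compound 3 is expected at 10000 nM, with an estimated range of 4500 nM to 22000 nM. The expected change is a 1.1-fold lower number from compound 2 to compound 3 (0.03 log units; within the scatter).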

Compound 3, half-maximal inhibitory concentration: 7320 nM
Compound 3: middle estimate off by 1.4-fold (0.14 log units), on the high side, and the stated range covers the measured number.
By their numbers in this assay, from the lowest: compounds 3, 1 and 2 (each within the scatter of the next).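

In this assay, extending the group on the carbonyl carbon from prop-1-en-1-yl to pent-1-en-1-yl gives a 1.5-fold lower number from compound 2 to compound 3 (0.17 log units; within the scatter), while pent-1-en-1-yl in place of 2-methylprop-1-en-1-yl gives a 1.1-fold lower number from compound 1 to compound 3 (0.03 log units; within the scatter). Ethyl in place of hydrogen on a saturated chain carbon bound to a double-bonded chain carbon therefore produces no step beyond the scatter, and the three groups on the carbonyl carbon cannot be ranked on these numbers. No measured evidence accounts for this result.

On these data alone, it remains open whether a longer chain, or an amine or a carboxylic acid carried on this chain, would produce a step beyond the scatter. As far as these compounds go, what a fully saturated chain such as propyl on the carbonyl carbon would give is equally open.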